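The source may hold more compounds than are shown below. What is called first, only, known or untested is meant among the compounds shown, and "the series" means these compounds.

Measured so far:
- Compound 1, `Cc1c(OCCCCOc2ccc(Cl)c(C(=O)O)c2)ccc(C(=O)CC(C)(C)C)c1O`, in an assay for positive allosteric modulation of metabotropic glutamate receptor 3 (Rattus norvegicus); on this read-out lower numbers stand for an effect already at smaller amounts and higher numbers for an effect only at larger amounts of compound: 130 nM
- Compound 2, `COc1ccc(C(=O)O)cc1OC[C@@H](C)COc1ccc(C(=O)CC(C)(C)C)c(O)c1C`, in this assay: 1040 nM
- Compound 3, `COc1ccc(C(=O)O)cc1OC[C@H](C)COc1ccc(C(=O)CC(C)(C)C)c(O)c1C`, in this assay: 384 nM

Compound 3 stands second highest of the three numbers. Its nearest neighbour is compound 2, separated by a 2.7-fold lower number from compound 2 to compound 3 (0.43 log units; beyond the scatter), a step that rests on (the fact that compounds 2 and 3 differ only in the configuration as drawn). Compound 1 lies furthest from it, with the lowest number of the set.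

The next compound, compound 4, has the structure `COc1ccccc1OC[C@H](C)COc1ccc(C(=O)CC(C)(C)C)c(O)c1C`. The change from compound 3 is hydrogen in place of carboxy on an aromatic carbon. Among the compounds with values here, none of the measured steps touches this part of the molecule; the only step in hand, from compound 2 to compound 3, concerns a stereocentre elsewhere and so gives no direct guide to the size of the step in this assay. From the compounds shown here alone, all three measured compounds carry the carboxy group, so its removal is untested. The author expects compound 4 to give a higher number, with a 3.1-fold higher number from compound 3 to compound 4 (0.49 log units; beyond the scatter) as the estimated step. For compound 4 the estimate in this assay is 1200 nM, with a range from 300 nM to 5000 nM.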

Compound 4, half-maximal effective concentration: "not active" (no number reported)
Nothing numeric was reported for compound 4; no gap can be computed for the estimate.
By their numbers in this assay, from the lowest: compound 1; then compound 3; then compound 2.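

In this assay, within the data shown here, compound 4 is recorded as "not active" with no number, so no step from compound 3 can be read. The compounds shown leave open how large that gap is and whether carboxy matters equally in the other configuration. Nothing in hand bears on this result.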